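A few compounds are considered here, and "the series" means these few. Any claim that something is new, unique, unknown or untested is made for them only; others in the source may bear on it.

Compound 1 `Cc1ccc(CN2CCN(c3cccc4[nH]c(-c5ccc(C(C)(C)C)cc5)nc34)CC2)o1` and compound 2 `Cc1nc(C)c(CN2CCN(c3cccc4[nH]c(-c5ccc(C(C)(C)C)cc5)nc34)CC2)o1` share one core and differ only in the ring carried on the saturated chain carbon. In an assay on isolated protein for displacement of a labelled ligand from Gonadotropin-releasing hormone receptor (Homo sapiens) (a lower number here means a stronger inhibitor, a higher number a weaker inhibitor), compound 1 gives 705 nM, while compound 2 gives 31 nM, the lowest of the two numbers; the step of a 23-fold lower number from compound 1 to compound 2 (1.36 log units; beyond the scatter) lies beyond the scatter. Compound 3 `Cc1nc(CN2CCN(c3cccc4[nH]c(-c5ccc(C(C)(C)C)cc5)nc34)CC2)c(C)s1` differs from compound 2 by 2,5-dimethyl-1,3-thiazol-4-yl in place of 2,4-dimethyl-1,3-oxazol-5-yl on a saturated chain carbon bound to an amine nitrogen in a ring. Among the measured compounds shown here, no measured step covers a 2,5-dimethyl-1,3-thiazol-4-yl in place of a 2,4-dimethyl-1,3-oxazol-5-yl; the only known step, a 23-fold lower number from compound 1 to compound 2 (1.36 log units; beyond the scatter), swapped a different ring. Compound 3 is therefore expected to show a step of a 1.3-fold higher number from compound 2 to compound 3 (0.11 log units; within the scatter) within the scatter. Compound 3 is estimated at 40 nM, between 12 nM and 130 nM.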

Compound 3, half-maximal inhibitory concentration: 21 nM
Compound 3: middle estimate off by 1.9-fold (0.28 log units), on the high side; the range from low to high includes it.
By their numbers in this assay, from the lowest: compounds 3 and 2 (each within the scatter of the next); then compound 1.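

In this assay, 2,5-dimethyl-1,3-thiazol-4-yl and 2,4-dimethyl-1,3-oxazol-5-yl are interchangeable at this position (a 1.5-fold lower number from compound 2 to compound 3 (0.17 log units; within the scatter)). The large difference from 5-methylfuran-2-yl therefore extends beyond a single ring (a 34-fold lower number from compound 1 to compound 3 (1.53 log units; beyond the scatter)). No supporting evidence explains why these two rings match or why both differ from 5-methylfuran-2-yl.

Open, going by these compounds, is how much the two methyl groups contribute, which an unsubstituted thiazol-4-yl would address. Also open, on these data alone, is whether a six-membered ring such as pyridin-3-yl would hold the number.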